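The source may report more compounds than this note shows. Statements on the series, on what has been measured and on what is new or still open speak of the compounds shown alone.

Compound 1 `O=S(=O)(NCCCNCc1ccccc1Cl)c1cc(C(F)(F)F)cc(C(F)(F)F)c1`: 11000 nM
Compound 2 `CN(CCCNS(=O)(=O)c1cc(C(F)(F)F)cc(C(F)(F)F)c1)Cc1ccccc1`: 39000 nM
Compound 3 `O=S(=O)(NCCCNCc1cccc(Cl)c1)c1cc(C(F)(F)F)cc(C(F)(F)F)c1`: 3800 nM

Of the compounds shown here, three sharing one core have been measured in a functional assay on BXPC-3 cells (Homo sapiens) for inhibition, read by MTT assay, with a stated time of 72 h; on this read-out higher numbers stand for weaker inhibition of growth and lower numbers for stronger inhibition of growth. Compound 1 holds the second highest of the three numbers: its nearest neighbour is compound 3, reached by a 2.9-fold lower number from compound 1 to compound 3 (0.46 log units; beyond the scatter), and its furthest is compound 2, reached by a 3.5-fold higher number from compound 1 to compound 2 (0.55 log units; beyond the scatter). Between those two, the step of a 10-fold lower number from compound 2 to compound 3 (1.01 log units; beyond the scatter) is the largest seen so far.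

Compound 4 `COc1cccc(CNCCCNS(=O)(=O)c2cc(C(F)(F)F)cc(C(F)(F)F)c2)c1` has not been measured. It differs from compound 1 in one place: 3-methoxyphenyl in place of 2-chlorophenyl on a saturated chain carbon bound to an amine nitrogen. Within the data shown here, the step that bears most directly on this change is the one from compound 1 to compound 3, where moving the chlorine from the 2-chlorophenyl to the 3-chlorophenyl position on the same saturated chain carbon gave a 2.9-fold lower number from compound 1 to compound 3 (0.46 log units; beyond the scatter). Compound 4 carries its substituent at the same position as compound 3, though the group is 3-methoxyphenyl rather than 3-chlorophenyl, and nothing measured tells how that exchange behaves. A modest lowering of the number in this assay is therefore expected, of roughly the size a 2.2-fold lower number from compound 1 to compound 4 (0.34 log units; beyond the scatter), though a result within the scatter of compound 1 cannot be excluded. Compound 4 is estimated at 5000 nM, with a likely range from 2000 nM to 15000 nM.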

Compound 4, concentration for 50% growth inhibition: 1700 nM
Compound 4: the middle estimate sits 2.9-fold (0.47 log units) above what was measured; measured number outside the range, below it.
By their numbers in this assay, from the lowest: compound 4; then compound 3; then compound 1; then compound 2.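

Among these compounds, with 3-methoxyphenyl on a saturated chain carbon bound to an amine nitrogen, this assay gives a 6.5-fold lower number from compound 1 to compound 4 (0.81 log units; beyond the scatter) and this step exceeds the one to the 3-chlorophenyl group of compound 3, so the number at this position depends on the group itself and not only on where it stands on the ring. Methoxy in place of chloro on an aromatic carbon gives a 2.2-fold lower number from compound 3 to compound 4 (0.35 log units; beyond the scatter) and thus adds a comparison the earlier compounds lacked, leaving compound 4 the lowest of the four, with its steps to all the others beyond the scatter. The widest gap in the set is now a 23-fold lower number from compound 2 to compound 4 (1.36 log units; beyond the scatter) for (3-methoxybenzyl)amino in place of benzyl(methyl)amino, and no supporting evidence is available to explain any of these steps.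

The compounds shown leave open how a 2-methoxyphenyl or 4-methoxyphenyl group would compare with 3-methoxyphenyl, and whether an ethoxy or hydroxy group would do better or worse than methoxy. They also leave open what the methyl on the amine of compound 2 contributes apart from the missing ring substituent, and how a longer chain would behave.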